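Pyrazole series: amide-to-urea step on the anilide arm

A few compounds are considered here, and "the series" means these few. Any claim that something is new, unique, unknown or untested is made for them only; others in the source may bear on it.

Measured compounds in this series:
compound 1 `O=C(Nc1cccc(-n2cc(-c3ccncc3)c(-c3ccc(Cl)c(O)c3)n2)c1)Nc1ccc(Cl)c(Cl)c1` — "not determined" (no result reported)
compound 2 `COc1cc(-c2nn(-c3cccc(NC(=O)c4cccc(C(F)(F)F)c4)c3)cc2-c2ccncc2)ccc1Cl` — 1020 nM
compound 3 `O=C(Nc1cccc(-n2cc(-c3ccncc3)c(-c3ccc(Cl)c(O)c3)n2)c1)Nc1cc(C(F)(F)F)cc(C(F)(F)F)c1` — 620 nM

In a functional assay on SF-295 cells (Homo sapiens) for inhibition, read by sulforhodamine B assay, with a stated time of 48 h (a lower number here means a stronger inhibitor, a higher number a weaker inhibitor), compound 2 gives 1020 nM. Among the two numbers available, compound 2 has the highest, but its nearest neighbour, compound 3, gives 620 nM in this assay, and that gap lies within the usual scatter, so no order between compound 2 and compound 3 can be stated. Compound 1 carries no result in this assay, so it adds nothing to the comparison.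

The step now considered leads from compound 2 to compound 4 `COc1cc(-c2nn(-c3cccc(NC(=O)Nc4ccc(Cl)c(C(F)(F)F)c4)c3)cc2-c2ccncc2)ccc1Cl`. The change is (4-chloro-3-(trifluoromethyl)phenyl)amino in place of 3-(trifluoromethyl)phenyl on a carbonyl carbon. Among the measured compounds shown here, no directly comparable step between measured compounds is available, so the expectation rests on the two numbers alone, which sit close together and show that the two amide-type arms measured so far do not separate in this assay.

The step from compound 2 to compound 4 is therefore expected to be small, a 1.6-fold lower number from compound 2 to compound 4 (0.20 log units; within the scatter), toward a lower number at most and not clearly beyond the scatter. For compound 4 the estimate in this assay is 650 nM, with a range from 200 nM to 2000 nM.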

Compound 4, half-maximal inhibitory concentration: 840 nM
For compound 4 the middle estimate is 1.3-fold (0.11 log units) below the measured one; low and high end bracket the measured number.
By their numbers in this assay, from the lowest: compounds 3, 4 and 2 (each within the scatter of the next).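

In this assay, among the compounds shown here, the step on the carbonyl carbon gives the first direct reading at this position, a 1.2-fold lower number from compound 2 to compound 4 (0.08 log units; within the scatter), so replacing 3-(trifluoromethyl)phenyl with (4-chloro-3-(trifluoromethyl)phenyl)amino, which turns the amide-type arm into a urea arm, produces no readable difference. The earlier numbers could not show this: the two compounds with values differ in more than one place, and compound 1 has no number to pair with anything. No supporting measurement is at hand to account for the result or to assign it to any part of the change.

The step brings in an amino nitrogen with its hydrogen-bond donor and a chlorine together, so the compounds shown cannot separate the contribution of each, and opposing contributions that cancel remain as possible as two contributions that are both small. Also open, going by these compounds, is how this position reads in this assay with a group of a different kind on the carbonyl carbon, such as a piperidine or a short alkyl chain in place of the substituted aryl arm.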